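Swapping one five-membered ring group on compound 2

The source may hold more compounds than are shown below. What is called first, only, known or untested is meant among the compounds shown, and "the series" means these compounds.

In a physicochemical assay for solubility, read by LC-MS, in phosphate buffer, with a stated time of 24 h, at pH 7.4 (on this read-out higher numbers stand for higher solubility and lower numbers for lower solubility), three compounds have been measured so far. Compound 2 (`Cc1ncc(-c2cnc(NCc3c(F)ccc4c3CCO4)c3cn[nH]c(=O)c23)n1C`) reads 15000 nM and so lies within the scatter of compound 1 (`CN(C)Cc1ccc2c(c1)CN(c1cnc(NCc3c(F)ccc4c3CCO4)n3cnnc13)C2=O`) at 12000 nM on the same scale. Compound 3 (`CN(C(=O)c1ccccc1)c1cnc(NCc2c(F)ccc3c2CCO3)n2cnnc12`) stands apart at 280000 nM and lies beyond the scatter from compound 2.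

Compound 4 (`CNC(=O)c1cc(-c2cnc(NCc3c(F)ccc4c3CCO4)c3cn[nH]c(=O)c23)n(C)n1`) has not yet been measured and keeps the core of compound 2. The two differ in one group on an aromatic carbon of a six-membered aromatic ring with 1 nitrogen, where 1-methyl-3-(methylcarbamoyl)-1H-pyrazol-5-yl stands in place of 1,2-dimethyl-1H-imidazol-5-yl (1-methyl-3-(methylcarbamoyl)-1H-pyrazol-5-yl in place of 1,2-dimethyl-1H-imidazol-5-yl on an aromatic carbon).

Within the data shown here, no two measured compounds differ in only one place, so nothing yet shows directly how such a change behaves in this assay and the direction remains a judgement. With compound 2 at 15000 nM as the only measured anchor on this core, a moderate fall is expected rather than a rise. The estimated change is modest and only slightly beyond the scatter (a 2.5-fold lower number from compound 2 to compound 4 (0.40 log units; beyond the scatter)). Compound 4 is therefore estimated at 6000 nM (expected range 1500 nM to 25000 nM).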

Compound 4, solubility: 7000 nM
Estimate against measurement, compound 4: 1.2-fold (0.07 log units) below; low and high end bracket the measured number.
By their numbers in this assay, from the lowest: compounds 4, 1 and 2 (each within the scatter of the next, the first and the last beyond it); then compound 3.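

In this assay, among these compounds, this is the first pair of compounds that differ in only one place, and it shows that the position on an aromatic carbon of the six-membered aromatic ring with 1 nitrogen, para to a large group, responds to a change of group. Placing 1-methyl-3-(methylcarbamoyl)-1H-pyrazol-5-yl in place of 1,2-dimethyl-1H-imidazol-5-yl gives a 2.1-fold lower number from compound 2 to compound 4 (0.33 log units; beyond the scatter), a modest step for a group that brings 10 heavy atoms against 7 and 1 hydrogen-bond donor against 0. Nothing measured here accounts for the fall.

The single step changes the ring and adds the methylcarbamoyl group together, so the compounds shown leave open how much of it belongs to each, a question that a plain 1-methyl-1H-pyrazol-5-yl group at this position would address. They also leave open how a carboxylic acid or an amine in place of the methylcarbamoyl group would read, and whether the same swap would give a similar step on a core other than that of compound 2.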